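A Dopamine D4 Agonist Series: Changing the Piperidine Aryl Group

A few compounds are considered here, and "the series" means these few. Any claim that something is new, unique, unknown or untested is made for them only; others in the source may bear on it.

Compound 1 `Cc1cccc(NC(=O)CN2CCC(c3nccs3)CC2)c1`: 1 nM
Compound 2 `Cc1cccc(NC(=O)CN2CCC(c3cccc(C#N)n3)CC2)c1`: 36 nM

Of the compounds shown here, two have been measured in a functional assay on HEK293 cells for agonist activity at D(4) dopamine receptor (Homo sapiens), read by FLIPR; on this read-out higher numbers stand for an effect only at larger amounts of compound and lower numbers for an effect already at smaller amounts. Compound 1 `Cc1cccc(NC(=O)CN2CCC(c3nccs3)CC2)c1`, which carries a 1,3-thiazol-2-yl group on a saturated ring carbon, gives 1 nM. Compound 2 `Cc1cccc(NC(=O)CN2CCC(c3cccc(C#N)n3)CC2)c1`, which carries a 6-cyanopyridin-2-yl group at the same place, gives 36 nM, the highest of the two numbers; the step is a 36-fold higher number from compound 1 to compound 2 (1.56 log units; beyond the scatter).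

Compound 3 `Cc1cccc(NC(=O)CN2CCC(c3cccc(F)c3)CC2)c1` has not yet been measured. It differs from compound 2 by 3-fluorophenyl in place of 6-cyanopyridin-2-yl on a saturated ring carbon. Within the data shown here, only one step is known, and it exchanges one aromatic group for another at the same ring carbon, so it bears on this change only loosely; it shows that the group at this position can move the number well beyond the scatter. Among the measured compounds shown here, no measured pair tells how a 3-fluorophenyl group compares with a 6-cyanopyridin-2-yl group. With that caution, compound 3 is expected at roughly 15 nM, within a range of 3 nM to 80 nM, which would mean an estimated step of a 2.4-fold lower number from compound 2 to compound 3 (0.38 log units; beyond the scatter).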

Compound 3, half-maximal effective concentration: 512 nM
For compound 3 the middle estimate is 34-fold (1.53 log units) below the measured one, and the stated range ends below it.
By their numbers in this assay, from the lowest: compound 1; then compound 2; then compound 3.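

In this assay, among these compounds, the result shows that a six-membered aromatic ring of carbon only, 3-fluorophenyl, does not take the place of 6-cyanopyridin-2-yl on this saturated ring carbon without a large cost (a 14-fold higher number from compound 2 to compound 3 (1.15 log units; beyond the scatter)), a step that the earlier compounds could not foretell. Set against the 1,3-thiazol-2-yl group, the same group gives a much wider span at this one place (a 510-fold higher number from compound 1 to compound 3 (2.71 log units; beyond the scatter)), so among the three compounds the order of the numbers is now fixed and each gap lies beyond the scatter. No measurement on hand explains why these groups differ so strongly, so the result stands as an observation only.

The compounds shown leave open how much of the step from compound 2 to compound 3 belongs to the ring nitrogen, the nitrile or the fluorine, since all of these change together in that one exchange. From the compounds shown here alone, an unsubstituted phenyl group and an unsubstituted pyridin-2-yl group at the same ring carbon would separate these parts, and where either would fall in relation to compound 2 and compound 3 remains unknown.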